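This account rests on a few compounds, and the source may have more. Where it says the series, first, only, none or still open, it means among the compounds named here.

Measured so far:
- compound 1 `CCCCCCCCc1cn([C@H]2C[C@H](O)[C@@H](CO)O2)c(=O)[nH]c1=O` — 140 ug/mL
- compound 2 `CCCCCc1cn([C@H]2C[C@@H]3OP(=O)(O)OC[C@H]3O2)c(=O)[nH]c1=O` — > 500 ug/mL, an assay limit rather than a number

Among the compounds with values here, in a functional assay on Raji cells (Homo sapiens) (on this read-out higher numbers stand for weaker inhibition and lower numbers for stronger inhibition), compound 1 gives 140 ug/mL, and this is the only actual number in the set, so compound 1 stands as the sole fixed point. Compound 2 reaches only the limit of this assay, > 500 ug/mL, a limit and not a number; (the limit of > 500 ug/mL in this assay, at which 1 of the 2 values shown sits). Within the data shown here, compound 2 also differs from compound 1 in more than one place, so no measured step between any two compounds is available.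

Compound 3 `CCCc1cn([C@H]2C[C@H](O)[C@@H](CO)O2)c(=O)[nH]c1=O` is the next compound to be measured. It differs from compound 1 by hydrogen in place of pentyl on a saturated chain carbon, three bonds along the chain from an aromatic carbon. Among the measured compounds shown here, with no measured step to lean on, the expectation is a modest loss beyond the scatter, that is a higher number in this assay, for compound 3 relative to compound 1, the expected step being a 2.9-fold higher number from compound 1 to compound 3 (0.46 log units; beyond the scatter). Compound 3 is accordingly estimated at 400 ug/mL, with a range from 150 ug/mL to 1000 ug/mL, and a real chance that only a limit is reported.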

Compound 3, concentration for 50% inhibition: > 500 ug/mL
Compound 3: no number, only a limit; the forecaster's own chance of this, stated with the estimate: 40%; at least 1.2-fold (0.09 log units) between middle value and limit.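

Within the data shown here, replacing pentyl with hydrogen on a saturated chain carbon, three bonds along the chain from an aromatic carbon (octyl to propyl), gives the first readable step: an at least 3.5-fold higher number from compound 1 to compound 3 (0.55 log units; beyond the scatter) in this assay. Compound 3 gives only a limit, > 500 ug/mL, so this step sets a floor and not a size. The change therefore matters beyond the scatter at this place, and among the values shown only compound 1 holds an actual number: the limit of > 500 ug/mL in this assay, at which 2 of the 3 values shown sit.

The compounds shown leave open where between propyl and octyl on the core of compound 1 the read-out reaches the limit, and whether a longer chain such as decyl would give a lower number. They also leave open how a carboxylic acid or an amine at the chain end would read.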